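Compound 4 Swaps One Five-Membered Ring for Another

The source may hold more compounds than are shown below. What is called first, only, known or untested is meant among the compounds shown, and "the series" means these compounds.

Values so far in a physicochemical assay for solubility, measured as kinetic solubility, at pH 2; a higher number here means a more soluble compound, a lower number a less soluble compound
Compound 1 `CC(C)C(/C=C1\NC(=O)NC1=O)c1ccc(-c2ccc3cccc(F)c3c2)[nH]c1=O` gives 7500 nM
Compound 2 `Cc1cc(C(/C=C2\OC(=O)NC2=O)C(C)C)c(=O)[nH]c1-c1ccc2cccc(F)c2c1` gives 39400 nM
Compound 3 `CCC(CC)C(/C=C1\OC(=O)NC1=O)c1ccc(-c2ccc3cccc(F)c3c2)[nH]c1=O` gives 3680 nM

Compound 1 stands in the middle of these three numbers, with compound 2 higher at 39400 nM and compound 3 lower at 3680 nM and both gaps beyond the usual scatter of repeated measurements.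

Compound 4 `CC(C)C(c1ccc(-c2ccc3cccc(F)c3c2)[nH]c1=O)C1SC(=O)NC1=O` has not yet been measured. The change from compound 1 to compound 4 is a group of 7 heavy atoms (3 carbon, 1 nitrogen, 2 oxygen, 1 sulfur; one five-membered non-aromatic ring with 2 hetero atoms) in place of a group of 8 heavy atoms (4 carbon, 2 nitrogen, 2 oxygen; one five-membered non-aromatic ring with 2 hetero atoms), on a saturated chain carbon bound to an aromatic carbon and a saturated chain carbon and it brings in 2,4-dioxo-1,3-thiazolidin-5-yl as the new group. For the measured compounds named here, no two measured compounds differ in one place only, and none carries this new group, so nothing here measures the swap directly and any expectation stays loose. The expected size in this assay is no step beyond the scatter, with a slight lean toward a lower number, and the estimated 1.5-fold lower number from compound 1 to compound 4 (0.18 log units; within the scatter) is offered on that basis. For compound 4 the expected value is 5000 nM with 1500 nM to 17000 nM as its estimated range.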

Compound 4, solubility: 11300 nM
Beside the measured number, compound 4's estimate is 2.3-fold (0.35 log units) below it; low and high end bracket the measured number.
By their numbers in this assay, from the lowest: compound 3; then compounds 1 and 4 (each within the scatter of the next); then compound 2.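

For the compounds shown here, at this saturated chain carbon bound to an aromatic carbon and a saturated chain carbon, the pair gives the first single-place step that can be read in this assay and it shows a 1.5-fold higher number from compound 1 to compound 4 (0.18 log units; within the scatter) for the change to 2,4-dioxo-1,3-thiazolidin-5-yl. Within this one pair, a five-membered non-aromatic ring holding sulfur can therefore replace the earlier five-membered non-aromatic ring, which has two nitrogens, and the two compounds cannot be told apart on this read-out. Nothing available accounts for this outcome.

On these data alone, whether an amine or a carboxylic acid at this carbon would give a step beyond the scatter remains open. Also open, as far as these compounds go, is whether the same ring swap would give a similar step on the cores of compound 2 and compound 3.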